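Swapping the aryl group on the cinnamamide arm of compound 2

The source may hold more compounds than are shown below. What is called first, only, known or untested is meant among the compounds shown, and "the series" means these compounds.

Compound 2 `O=C(/C=C/c1cccs1)Nc1ccc2ncnc(Nc3cccc(Br)c3)c2c1` and compound 1 `COc1ccccc1/C=C/C(=O)Nc1ccc2ncnc(Nc3cccc(Br)c3)c2c1` share the same core and differ only in the aromatic ring at the end of the double-bonded chain. In a functional assay on A549 cells (Homo sapiens) for antiproliferative activity, read by MTT assay, with a stated time of 48 h (on this read-out lower numbers stand for stronger inhibition and higher numbers for weaker inhibition), compound 1 gives 3.55 ug/mL, and in this assay compound 2 gives 4.66 ug/mL. Of these two numbers compound 2 has the higher one, but the gap is small: the step of a 1.3-fold higher number from compound 1 to compound 2 (0.12 log units; within the scatter) stays within the scatter, so the two values cannot be told apart.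

Compound 3 `Cc1ccc(/C=C/C(=O)Nc2ccc3ncnc(Nc4cccc(Br)c4)c3c2)cc1` is the next member and has not yet been measured. Its difference from compound 2 is 4-methylphenyl in place of thiophen-2-yl on a double-bonded chain carbon bound to a double-bonded chain carbon. Among the compounds with values here, the only measured step that bears on this change is the one from compound 1 to compound 2, an exchange of the same ring at the same place, and that step was within the scatter. On that basis no change beyond the scatter is expected for compound 3 in this assay, so the expected step is a 1.1-fold lower number from compound 2 to compound 3 (0.05 log units; within the scatter). Compound 3 is therefore estimated at 4.2 ug/mL, with a range from 2 ug/mL to 9 ug/mL.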

Compound 3, half-maximal inhibitory concentration: 3.01 ug/mL
Beside the measured number, compound 3's estimate is 1.4-fold (0.14 log units) above it; measured number inside the range.
By their numbers in this assay, from the lowest: compounds 3, 1 and 2 (each within the scatter of the next).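

With compound 3, a third aromatic ring stands on a double-bonded chain carbon bound to a double-bonded chain carbon, and the comparison now covers two exchanges that both lead to 4-methylphenyl: in this assay, replacing thiophen-2-yl gives a 1.5-fold lower number from compound 2 to compound 3 (0.19 log units; within the scatter), and replacing 2-methoxyphenyl gives a 1.2-fold lower number from compound 1 to compound 3 (0.07 log units; within the scatter). Neither step can be distinguished from ordinary repeat variation, so thiophen-2-yl, a five-membered aromatic ring with a hetero atom, and the two substituted six-membered rings of this set cannot be told apart by this read-out. No supporting measurement is available to explain why these three compounds read alike.

All three groups at this position are aromatic rings without a charge, so these results say nothing about how a ring carrying an amine or a carboxylic acid would read. Going by these compounds, it also remains open whether a simple butyl chain in place of the ring would leave the number within the same scatter, and the shared core stays unchanged throughout, so nothing can be said about its other positions.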